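An Acetyl Group Added Where Only a Limit Is Known

The compounds below may be only part of what the source reports. "The series", "measured", "known", "first", "only" and "open" are said of these compounds alone.

Compound 1 `CC(=O)O[C@@H]1C[C@@H](OC(C)=O)C(C)(C)[C@H](O)[C@H]2O[C@@]3(C[C@H](C)[C@H](OC(=O)c4ccccc4)[C@@H]3/C=C/1C)[C@@H](OC(C)=O)[C@H]2C` and compound 2 `CC(=O)O[C@H]1[C@@H](C)/C=C/C(C)(C)[C@H](O)C[C@@H](O)/C(C)=C/[C@H]2[C@@H](OC(=O)c3ccccc3)[C@@H](C)C[C@@]21O` share a core and were both tested in a functional assay on MDA-MB-231 cells (Homo sapiens) for cytotoxicity, read by MTT assay; a higher number here means a weaker inhibitor, a lower number a stronger inhibitor. For compound 1 the assay reports no number, only a limit, > 10000 nM. For compound 2 the result is likewise only a limit, > 10000 nM. Both results therefore sit at the same edge of the assay, (the limit of > 10000 nM in this assay, at which 2 of the 2 values shown sit), so neither compound has a measured potency to compare.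

Compound 3 `CC(=O)O[C@@H]1C[C@@H](O)C(C)(C)/C=C/[C@H](C)[C@H](OC(C)=O)[C@@]2(O)C[C@H](C)[C@H](OC(=O)c3ccccc3)[C@@H]2/C=C/1C` has not yet been tested. It differs from compound 2 in one place (acetyl in place of hydrogen on an oxygen on a saturated carbon), a change that, read one bond further out, turns a hydroxy into an acetoxy. Among the measured compounds shown here, no measured pair shows the effect of such a change here, so the expected step from compound 2 is a step that the limit leaves unreadable from compound 2 to compound 3, with no direction expected beyond the usual scatter. Compound 3 is therefore estimated at 15000 nM, within a range from 3000 nM to 60000 nM, and most likely the assay will again report only a limit.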

Compound 3, half-maximal inhibitory concentration: > 10000 nM
Compound 3 ended at the assay's limit; the forecaster's own chance of this, stated with the estimate: 75%; the middle value is on the limit's open side.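

Compound 2 and compound 3 both give only a limit in this assay, not a number, so no step between them can be read: the limit of > 10000 nM in this assay, at which 3 of the 3 values shown sit.

The compounds shown leave open whether swapping hydroxy for acetoxy changes potency at all, and what potency any compound on the shared core has.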